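The source may hold more compounds than are shown below. What is called first, only, known or untested is meant among the compounds shown, and "the series" means these compounds.

Compound 1 `COC(=O)/C=C/c1cccc(N(Cc2ccc(-c3ccc(N(C)C)cc3)cc2)C(=O)C(C)C)c1`: in an assay on isolated protein with Bile acid receptor (Homo sapiens) as the target (on this read-out lower numbers stand for an effect already at smaller amounts and higher numbers for an effect only at larger amounts of compound), compound 1 gives 57 nM.
Compound 2 `COC(=O)/C=C/c1cccc(N(Cc2ccc(/C=C/C(=O)OC(C)(C)C)cc2OCc2ccccc2)C(=O)C2CCCCC2)c1`: in this assay compound 2 gives > 1000 nM, which is a limit of the assay and not a number.
Compound 3 `COC(=O)/C=C/c1cccc(N(Cc2ccc(/C=C/C(=O)OC(C)(C)C)cc2OC(C)=O)C(=O)C2CCCCC2)c1`: in this assay compound 3 gives > 1000 nM, again only a limit.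

Compound 3 therefore stands at the weak end of what is shown: it has no number of its own, only a limit, and compound 2 shares that situation. Only compound 1 has a readable value in this assay. Going by the values given here, the one measured step, a step that the two limits leave unreadable from compound 2 to compound 3, cannot be read because both of its ends sit at the limit of > 1000 nM in this assay, at which 2 of the 3 values shown sit.

Compound 4 `CCOC(=O)COc1cc(/C=C/C(=O)OC(C)(C)C)ccc1CN(C(=O)C1CCCCC1)c1cccc(/C=C/C(=O)OC)c1` differs from compound 3 in one place: (ethoxycarbonyl)methyl in place of acetyl on an oxygen on an aromatic ring. Among the compounds with values here, no measured step bears on this kind of change, and the one step that exists gives no size at all. With compound 3 sitting at the limit and nothing in the data pointing to a recovery, the expectation is that compound 4 stays in the same weak region, which means an expected step that the limit leaves unreadable from compound 3 to compound 4. Compound 4 is thus estimated at 2000 nM, within a range from 500 nM to 10000 nM.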

Compound 4, half-maximal effective concentration: > 1000 nM
Compound 4: a limit, no number; the forecaster's own chance of this, stated with the estimate: 70%; the middle value is on the limit's open side.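

Compound 4 gives only a limit, not a number, just as compound 2 and compound 3 do, so the steps among these three compounds cannot be read: the limit of > 1000 nM in this assay, at which 3 of the 4 values shown sit.

The compounds shown leave open how far apart these three truly lie, and whether changing the group on that oxygen matters at all.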